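The source may hold more compounds than are shown below. What is called first, only, known or untested is meant among the compounds shown, and "the series" means these compounds.

In a functional assay on K562 cells (Homo sapiens) for inhibition, read by trypan blue exclusion, with a stated time of 72 h (a lower number here means a stronger inhibitor, a higher number a weaker inhibitor), compound 1 (`Cn1c(=O)c(S(=O)(=O)c2ccc(Cl)cc2Cl)cc2cnc(Nc3ccc4[nH]ccc4c3)nc21`) gives 1000 nM and so holds the lowest of the three numbers measured. Compound 2 (`Cn1c(=O)c(S(=O)(=O)c2ccc(C(=O)O)cc2)cc2cnc(Nc3ccc4[nH]ccc4c3)nc21`) gives 5000 nM in the same test, and compound 3 (`O=c1c(S(=O)(=O)c2ccc(F)cc2F)cc2cnc(Nc3ccc4[nH]ccc4c3)nc2n1C1CCCC1`) gives 5000 nM there as well. Compound 4 (`Cn1c(=O)c(C(=O)Nc2ccc(F)cc2)cc2cnc(Nc3ccc4[nH]ccc4c3)nc21`) has not yet been measured. It differs from compound 1 in one place on the shared core, where (4-fluorophenyl)carbamoyl stands in place of (2,4-dichlorophenyl)sulfonyl on an aromatic carbon: (4-fluorophenyl)carbamoyl in place of (2,4-dichlorophenyl)sulfonyl on an aromatic carbon is the full count of that exchange. Within the data shown here, only one measured step touches this place, namely a 5.0-fold higher number from compound 1 to compound 2 (0.70 log units; beyond the scatter) with 4-carboxyphenyl in place of 2,4-dichlorophenyl on a sulfonyl sulfur. Among the measured compounds shown here, that step is modest, yet it keeps the sulfonyl, so it shows only that changing the outer ring at this place can move the number. For the measured compounds named here, no measured compound shows what replacing the sulfonyl itself does. Going by the values given here, with compound 2 at 5000 nM as the only guide, a modest upward move is expected here too, though with wide uncertainty. The expected change in this assay is a 2.5-fold higher number from compound 1 to compound 4 (0.40 log units; beyond the scatter) as a rough estimate. For compound 4 the estimated value is 2500 nM with an expected range from 700 nM to 9000 nM in this test.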

Compound 4, half-maximal inhibitory concentration: 5000 nM
Beside the measured number, compound 4's estimate is 2.0-fold (0.30 log units) below it; low and high end bracket the measured number.
By their numbers in this assay, from the lowest: compound 1; then compounds 2, 3 and 4 (each within the scatter of the next).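

In this assay the exchange gives a 5.0-fold higher number from compound 1 to compound 4 (0.70 log units; beyond the scatter), so the number moves when the sulfonyl link itself is replaced and not only when the outer ring changes. The earlier step at this place, a 5.0-fold higher number from compound 1 to compound 2 (0.70 log units; beyond the scatter), kept the sulfonyl and is printed at the same size, which means that two quite different changes here both leave the number higher than that of compound 1. In compound 4 the link and the ring substituents change together, with (4-fluorophenyl)carbamoyl bringing in the amide hydrogen as a hydrogen-bond donor, so this single step cannot divide the shift between the link and the ring. No measurement at hand explains the shift.

A (2,4-dichlorophenyl)carbamoyl group would keep the outer ring of compound 1 while changing only the link, and so would separate those two contributions. Also open, from the compounds shown here alone, is how much of the outer part matters at all, for example with a small amine or a carboxylic acid placed directly on this aromatic carbon.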